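Replacing an Amide with an Ester-Bearing Alkene

This account rests on a few compounds, and the source may have more. Where it says the series, first, only, none or still open, it means among the compounds named here.

Three compounds share one core, and each carries a different group on the same aromatic carbon. Compound 1 `COC(=O)c1ccc(-c2nn(Cc3ccccc3)c3ccccc23)cc1`, compound 2 `CCCOC(=O)c1ccc(-c2nn(Cc3ccccc3)c3ccccc23)cc1` and compound 3 `CCCNC(=O)c1ccc(-c2nn(Cc3ccccc3)c3ccccc23)cc1` were tested in a functional assay on cells (Platelet, Homo sapiens) for inhibition; a higher number here means a weaker inhibitor, a lower number a stronger inhibitor. In this assay compound 1 gives only a limit of > 10000 nM. In this assay compound 2 likewise gives only a limit of > 10000 nM. In this assay compound 3 too gives only a limit of > 10000 nM. Because all three sit at the limit of > 10000 nM in this assay, at which 3 of the 3 values shown sit, none of the steps between them can be sized: a step that the two limits leave unreadable from compound 1 to compound 2, a step that the two limits leave unreadable from compound 1 to compound 3 and a step that the two limits leave unreadable from compound 2 to compound 3. Compound 3 therefore stands at the limit, alongside the other two.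

Compound 4 `CCOC(=O)/C=C/c1ccc(-c2nn(Cc3ccccc3)c3ccccc23)cc1` differs from compound 3 by 2-(ethoxycarbonyl)ethenyl in place of propylcarbamoyl on an aromatic carbon. The three unreadable steps give no direction for this change; they only show that neither an ester nor an amide on this carbon produced measurable inhibition. The entering group again carries an ester. The step from compound 3 to compound 4 is therefore expected to be small, a step that the limit leaves unreadable from compound 3 to compound 4. Compound 4 is estimated at 15000 nM, between 3000 nM and 60000 nM, with a fair chance that only a limit is reported again.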

Compound 4, half-maximal inhibitory concentration: > 10000 nM
Compound 4 gave a limit, no number; the forecaster's own chance of this, stated with the estimate: 70%; the middle value does not contradict the limit.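

In this assay compound 4 gives only a limit, > 10000 nM. The steps to compound 4 from compound 1, compound 2 and compound 3 therefore cannot be read: the limit of > 10000 nM in this assay, at which 4 of the 4 values shown sit.

The compounds shown leave open whether any group on this aromatic carbon gives measurable inhibition in this assay.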